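The compounds below may be only part of what the source reports. "The series", "measured", "known", "first", "only" and "open" are said of these compounds alone.

The series is built on the shared core of compound 1, `CCOC(=O)C12C(=O)OCC=C1COC2c1ccccc1F`, in which an aryl group sits on a saturated ring carbon of the oxygen-bearing five-membered ring. In a functional assay on QGY cells (Homo sapiens) for cytotoxicity, read by MTT assay (a higher number here means a weaker inhibitor, a lower number a stronger inhibitor), compound 1 gives only a limit of the assay, > 1000000 nM, and not a number. Compound 2, `CCOC(=O)C12C(=O)OCC=C1COC2c1ccc(OC)c(OC)c1`, carries a 3,4-dimethoxyphenyl group at the same place. In this assay compound 2 likewise gives only a limit, > 1000000 nM. Compound 3, `CCOC(=O)C12C(=O)OCC=C1COC2c1ccc(N(C)C)cc1`, bears a 4-(dimethylamino)phenyl group there. In this assay compound 3 also returns only a limit, > 1000000 nM. So compound 1 stands where all its companions stand: the limit of > 1000000 nM in this assay, at which 3 of the 3 values shown sit, and no ranking among the three is possible.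

Compound 4, `CCOC(=O)C12C(=O)OCC=C1COC2c1ccco1`, differs from compound 1 by furan-2-yl in place of 2-fluorophenyl on a saturated ring carbon. Within the data shown here, no measured step between two compounds exists to gauge such a change, and the three aryl variants seen so far all sit at the limit. The expected step from compound 1 to compound 4 in this assay is therefore a number no higher from compound 1 to compound 4 (the limit leaves the size open), none beyond the scatter. Compound 4 is estimated in this assay at 1000000 nM, with a range from 200000 nM to 5000000 nM, and most likely the assay again reports only a limit.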

Compound 4, half-maximal inhibitory concentration: > 1000000 nM
Compound 4 gave a limit, no number; the forecaster's own chance of this, stated with the estimate: 85%; the middle value sits exactly at the limit.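

Among these compounds, compound 4 gives only a limit in this assay of > 1000000 nM and not a number, so no step between compound 1 and compound 4 can be read: the limit of > 1000000 nM in this assay, at which 4 of the 4 values shown sit. The compounds shown leave open how the four rank among themselves in this assay and whether any group at this place on the shared core would give a measurable value there.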